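This account rests on a few compounds, and the source may have more. Where it says the series, first, only, none or still open, it means among the compounds named here.

In a functional assay on MDA-MB-231 cells (Homo sapiens) for antiproliferative activity, read by MTT assay, with a stated time of 48 h (on this read-out higher numbers stand for weaker inhibition and lower numbers for stronger inhibition), compound 1 (`COc1ccc(N(C)c2ccnc(Cl)n2)cc1`) gives 2820 nM. Compound 2 (`COc1ccc(N(C)c2ccnc(Cl)n2)cc1O`), with hydroxy in place of an aromatic hydrogen, gives 833 nM, which is a 3.4-fold lower number from compound 1 to compound 2 (0.53 log units; beyond the scatter). Compound 3 (`COc1ccc(N(C)c2ccnc(Cl)n2)cc1OCCBr`), with 2-bromoethoxy at that carbon, gives 6620 nM, the highest number of the three. That placing reflects a 2.3-fold higher number from compound 1 to compound 3 (0.37 log units; beyond the scatter) and a 7.9-fold higher number from compound 2 to compound 3 (0.90 log units; beyond the scatter).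

Compound 4 (`COc1ccc(N(C)c2ccnc(Cl)n2)cc1OCC[Se]C#N`) keeps the chain of compound 3 but replaces its bromine: a group of 3 heavy atoms (1 carbon, 1 nitrogen, 1 selenium; no ring) in place of one bromine atom, on a saturated chain carbon, two bonds along the chain from an oxygen on an aromatic ring. For the measured compounds named here, no measured step changes the bromine itself, so these steps bear on the question only indirectly. They show how far the number has moved in this small set, not what the new group will do. The return to lower numbers seen in compound 1 at 2820 nM and the size of a 7.9-fold higher number from compound 2 to compound 3 (0.90 log units; beyond the scatter) suggest a modest shift, and the direction is uncertain. A move towards a lower number is favoured, and the expected step is a 3.7-fold lower number from compound 3 to compound 4 (0.57 log units; beyond the scatter). The estimate for compound 4 is 1800 nM, with an expected range from 350 nM to 7000 nM.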

Compound 4, half-maximal inhibitory concentration: 2750 nM
Compound 4: middle estimate off by 1.5-fold (0.18 log units), on the low side, and the stated range covers the measured number.
By their numbers in this assay, from the lowest: compound 2; then compounds 4 and 1 (each within the scatter of the next); then compound 3.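

Changing only the end of the chain moves the number in this assay (a 2.4-fold lower number from compound 3 to compound 4 (0.38 log units; beyond the scatter)), so the 2-bromoethoxy chain of compound 3 does not by itself fix the result: what replaces the bromine matters at this saturated chain carbon. With the new end group, the whole chain on the aromatic carbon cannot be told apart from the hydrogen it replaces (a 1.0-fold lower number from compound 1 to compound 4 (0.01 log units; within the scatter)). The free hydroxy keeps its lead over this chain on the same oxygen (a 3.3-fold higher number from compound 2 to compound 4 (0.52 log units; beyond the scatter)), so this replacement of the bromine does not recover the number of compound 2.

Nothing given here accounts for these shifts. As far as these compounds go, whether an amine in place of the bromine, or a longer chain carrying the same selenium and nitrile end group, would bring the number closer to that of compound 2 remains open.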